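The source may report more compounds than this note shows. Statements on the series, on what has been measured and on what is new or still open speak of the compounds shown alone.

For the measured compounds named here, compound 3 `CC(C)(C)n1ncc(OCc2nnc(-c3c(F)cccc3F)o2)c(Cl)c1=O` gives 45400 nM in a functional assay on the whole organism for inhibition, with Mythimna separata as the target, with a stated time of 5 days (a lower number here means that less compound is needed, a higher number that more compound is needed for the effect), the only actual number among the three measured compounds. Compound 1 `CCn1ncc(OCc2nnc(-c3ccccc3)o2)c(Cl)c1=O` reaches only the limit of > 299000 nM in this assay. Compound 2 `CC(C)(C)n1ncc(OCc2nnc(-c3cccs3)o2)c(Cl)c1=O` likewise stops at the limit of > 299000 nM in this assay. Compound 4 `CC(C)(C)n1ncc(OCc2nnc(-c3ccccc3)o2)c(Cl)c1=O` differs from compound 3 by phenyl in place of 2,6-difluorophenyl on an aromatic carbon. Going by the values given here, the one measured step that bears on this change is an at least 6.5-fold lower number from compound 2 to compound 3 (0.81 log units; beyond the scatter), where an aryl group without fluorine was weaker; compound 1, also carrying a plain phenyl, sits at the limit of > 299000 nM in this assay, at which 2 of the 3 values shown sit. A clearly higher number is therefore expected for compound 4 in this assay, by an estimated 5.5-fold higher number from compound 3 to compound 4 (0.74 log units; beyond the scatter). The estimate for compound 4 is 250000 nM, between 80000 nM and 600000 nM, with a real chance that only a limit is returned.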

Compound 4, half-maximal effective concentration: 12200 nM
Estimate against measurement, compound 4: 20-fold (1.31 log units) above; measured number below the stated range.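

At this place on the five-membered ring, plain phenyl outperforms 2,6-difluorophenyl (a 3.7-fold lower number from compound 3 to compound 4 (0.57 log units; beyond the scatter)), so the fluorines are not needed for activity here. Phenyl also outperforms thiophen-2-yl (an at least 24-fold lower number from compound 2 to compound 4 (1.38 log units; beyond the scatter)), and on the aromatic nitrogen tert-butyl outperforms ethyl (an at least 24-fold lower number from compound 1 to compound 4 (1.38 log units; beyond the scatter)). Both of these larger steps start from a limit rather than a number: the limit of > 299000 nM in this assay, at which 2 of the 4 values shown sit. The compounds shown leave open whether a phenyl carrying a single fluorine, a chlorine or a methoxy group would do better still. They also leave open how isopropyl or cyclopropyl would fare on the nitrogen.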